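Replacing bromo with amino in compound 1

The compounds below may be only part of what the source reports. "The series", "measured", "known", "first", "only" and "open" are said of these compounds alone.

Values measured in a functional assay on A549 cells (Homo sapiens) for antiproliferative activity, read by MTT assay, with a stated time of 48 h (on this read-out lower numbers stand for stronger inhibition and higher numbers for weaker inhibition), follow
compound 1 `COc1ccc(C(=O)c2ccc3c(c2)C=CC(C)(C)O3)c(NC(=O)CBr)c1` gives 1980 nM
compound 2 `COc1ccc(C(=O)c2ccc(OC)c3c2OC(C)(C)C=C3)c(NC(=O)CN)c1` gives 270 nM
compound 3 `COc1ccc(C(=O)c2ccc(OC)c3c2C=CC(C)(C)O3)c(NC(=O)CN)c1` gives 420 nM

Compound 1 carries the highest number of the three, and its gaps to compound 2 and compound 3 both lie beyond the scatter. Compound 4 `COc1ccc(C(=O)c2ccc3c(c2)C=CC(C)(C)O3)c(NC(=O)CN)c1` has not yet been measured. It departs from compound 1 through one change amino in place of bromo on a saturated chain carbon bound to a carbonyl carbon with amino in place of bromo on a saturated chain carbon bound to a carbonyl carbon. Within the data shown here, no measured pair isolates this change. Compound 2 at 270 nM and compound 3 at 420 nM already hold the amino group, although their cores differ from that of compound 1. A fall in this assay beyond the scatter is therefore expected. The estimated step is a 4.4-fold lower number from compound 1 to compound 4 (0.64 log units; beyond the scatter) on this reasoning. Compound 4 is estimated at 450 nM with an expected range from 150 nM to 1400 nM in this measure.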

Compound 4, half-maximal inhibitory concentration: 310 nM
Compound 4: middle estimate off by 1.5-fold (0.16 log units), on the high side; measured number inside the range.
By their numbers in this assay, from the lowest: compounds 2, 4 and 3 (each within the scatter of the next); then compound 1.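

In this assay, amino in place of bromo on a saturated chain carbon bound to a carbonyl carbon brings a 6.4-fold lower number from compound 1 to compound 4 (0.81 log units; beyond the scatter) on the shared core. Among these compounds, this pair gives the first reading of the change with the core held constant, which the earlier compounds, with their differing cores, could not give. No measurement shown here accounts for the step. The compounds shown leave open whether a dimethylamino group, a hydroxyl group or a longer chain ending in an amine at this place would keep the number of compound 4.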